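This account rests on a few compounds, and the source may have more. Where it says the series, first, only, none or still open, it means among the compounds named here.

Measured in a functional assay on DU-145 cells (Homo sapiens) for inhibition, read by trypan blue exclusion, with a stated time of 96 h; on this read-out higher numbers stand for weaker inhibition of growth and lower numbers for stronger inhibition of growth:
- compound 1 `O=C(/C(=C\c1ccc(O)c([N+](=O)[O-])c1)SCc1ccc(Br)cc1)c1ccc(Br)cc1`: 10000 nM
- compound 2 `O=C(/C(=C\c1cc(I)c(O)c(I)c1)SCc1ccc(Br)cc1)c1ccc(Br)cc1`: 1000 nM
- compound 3 `Cc1ccsc1/C=C(/SCc1ccc(Cl)cc1Cl)C(=O)c1ccc(Cl)cc1`: 10000 nM

Compound 1 gives 10000 nM, the same number as compound 3 at 10000 nM, and these two share the highest number of the three. Compound 4 `O=C(/C(=C\c1ccc(O)c([N+](=O)[O-])c1)SCc1ccc(Br)cc1)c1ccc(O)cc1O` keeps the core of compound 1 and differs in one place: 2,4-dihydroxyphenyl in place of 4-bromophenyl on a carbonyl carbon. In words, it has 2,4-dihydroxyphenyl in place of 4-bromophenyl on a carbonyl carbon.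

For the measured compounds named here, only one measured step is available, a 10-fold lower number from compound 1 to compound 2 (1.00 log units; beyond the scatter). That change lies on a double-bonded chain carbon, not on the carbonyl carbon, so it bears on compound 4 only indirectly. It shows how far numbers can move within this small set, but it gives no direction for the new change. Going by the values given here, no measured compound varies the group on the carbonyl carbon alone. In this assay, the expected outcome is therefore little net movement, with wide uncertainty in both directions, and the expected step is a 1.3-fold lower number from compound 1 to compound 4 (0.10 log units; within the scatter). The estimated value for compound 4 is 8000 nM, with an expected range of 2000 nM to 30000 nM.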

Compound 4, concentration for 50% growth inhibition: > 100000 nM
Compound 4 ended at the assay's limit; the forecaster's own chance of this, stated with the estimate: 25%; at least 12-fold (1.09 log units) between middle value and limit.
By their numbers in this assay, from the lowest: compound 2; then compounds 1 and 3 (each within the scatter of the next). At a limit, above all of these: compound 4.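

In this assay, the group on the carbonyl carbon proves able to move the read-out strongly: 2,4-dihydroxyphenyl in place of 4-bromophenyl gives an at least 10-fold higher number from compound 1 to compound 4 (1.00 log units; beyond the scatter), the only step shown at this position. Set against a 10-fold lower number from compound 1 to compound 2 (1.00 log units; beyond the scatter), a change on a double-bonded chain carbon, it shows that single changes to the core of compound 1 can shift the number in either direction. The value of compound 4 is a limit and not a number, so the step gives only a minimum size: the limit of > 100000 nM in this assay, at which 1 of the 4 values shown sits.

The compounds shown do not separate the departure of the bromine from the arrival of the two hydroxyl groups. On these data alone, how a plain phenyl or a 4-aminophenyl on the carbonyl carbon would read, and whether a single hydroxyl group would be enough for such a step, remains open.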